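Compound 3 to compound 4: one aryl group exchanged

The source may hold more compounds than are shown below. What is called first, only, known or untested is meant among the compounds shown, and "the series" means these compounds.

Compound 1 `CN1CCN(CCCOc2cccc3nc(Nc4ccc(Cl)c(F)c4)ccc23)CC1`: 1790 nM
Compound 2 `CC(C)c1ccc(Nc2ccc3c(OCCCN4CCN(C)CC4)cccc3n2)cc1`: 3630 nM
Compound 3 `CN1CCN(CCCOc2cccc3nc(Nc4ccc(F)c(F)c4)ccc23)CC1`: 4640 nM

All three values come from a functional assay on SF-295 cells (Homo sapiens) for inhibition, read by sulforhodamine B assay, with a stated time of 48 h; on this read-out higher numbers stand for weaker inhibition of growth and lower numbers for stronger inhibition of growth. Compound 3 gives the highest number of the set, although it lies within the scatter of compound 2, with a 1.3-fold higher number from compound 2 to compound 3 (0.11 log units; within the scatter). Its distance from the lowest number is clearer, with a 2.6-fold higher number from compound 1 to compound 3 (0.41 log units; beyond the scatter).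

Compound 4 `CN1CCN(CCCOc2cccc3nc(Nc4cccc(Cl)c4)ccc23)CC1` has not yet been measured. It carries 3-chlorophenyl in place of 3,4-difluorophenyl on a nitrogen on an aromatic ring.

The nearest guide is the exchange of chloro and fluoro between compound 1 and compound 3, seen in a 2.6-fold higher number from compound 1 to compound 3 (0.41 log units; beyond the scatter). Read in reverse, this points to a lower number for a chlorinated ring. The other measured steps, a 2.0-fold higher number from compound 1 to compound 2 (0.31 log units; beyond the scatter) and a 1.3-fold higher number from compound 2 to compound 3 (0.11 log units; within the scatter), show only a narrow spread across these aryl groups. Within the data shown here, no measured step isolates the loss of a fluoro group, so a modest change is expected in this assay, and it may stay within the scatter. The expected change is a 1.5-fold lower number from compound 3 to compound 4 (0.19 log units; within the scatter).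

For compound 4 the estimated value is 3000 nM, with an expected range from 1400 nM to 6500 nM.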

Compound 4, concentration for 50% growth inhibition: 1910 nM
For compound 4 the middle estimate is 1.6-fold (0.20 log units) above the measured one, within the range that was stated.
By their numbers in this assay, from the lowest: compounds 1, 4, 2 and 3 (each within the scatter of the next, the first and the last beyond it).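

In this assay, the change from 3,4-difluorophenyl to 3-chlorophenyl gives a 2.4-fold lower number from compound 3 to compound 4 (0.39 log units; beyond the scatter), showing that this position can respond beyond the scatter to a ring with one chloro group and no fluoro group. The fluoro group of the 4-chloro-3-fluorophenyl ring adds no measurable gain, with a 1.1-fold higher number from compound 1 to compound 4 (0.03 log units; within the scatter), and 3-chlorophenyl also stays within the scatter of 4-isopropylphenyl, with a 1.9-fold lower number from compound 2 to compound 4 (0.28 log units; within the scatter), so a ring without chloro goes against any simple link between chloro and a lower number. Nothing shown here gives a reason for these shifts.

The compounds shown leave open whether chloro itself or the loss of fluoro accounts for the step from compound 3, since neither a plain phenyl nor a 3-fluorophenyl ring appears among them. They also leave open how a 3-bromophenyl or 3-methoxyphenyl ring would read at this nitrogen.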